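Compound 3 to compound 4: a new side chain

The source may hold more compounds than are shown below. What is called first, only, known or untested is meant among the compounds shown, and "the series" means these compounds.

In an ADME assay on microsomes from liver (Mus musculus) for metabolic stability (on this read-out higher numbers stand for a longer-lived compound and lower numbers for a shorter-lived compound), compound 3 `CC(C)C(c1cnc(N)s1)c1ccc(-c2ccc3cccc(F)c3c2)[nH]c1=O` gives 0.08 h, level with compound 1 `CC(C)C(c1ncco1)c1ccc(-c2ccc3cccc(F)c3c2)[nH]c1=O` at 0.08 h. Compound 2 `CCn1ncc2c(F)cc(-c3ccc(C(CC)(CC)c4nncn4C)c(=O)[nH]3)cc21` reads > 3 h, which is a limit of the assay and not a number. Among the measured compounds shown here, no measured step links compound 2 to compound 3.

Compound 4 `CC(C)NC(=O)CC(c1ccc(-c2ccc3cccc(F)c3c2)[nH]c1=O)C(C)C` carries the change (isopropylcarbamoyl)methyl in place of 2-amino-1,3-thiazol-5-yl on a saturated chain carbon bound to an aromatic carbon and a saturated chain carbon. For the measured compounds named here, the one measured step at this place shows no change at the digits printed from compound 1 to compound 3 (within the scatter). As far as these compounds go, that step exchanged one ring for another, so a group without a ring remains untested here. In this assay the expected step is a 1.3-fold higher number from compound 3 to compound 4 (0.10 log units; within the scatter), none beyond the scatter. Compound 4 is estimated at 0.1 h, with an expected range of 0.05 h to 0.3 h.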

Compound 4, half-life: < 0.0667 h
Compound 4: a limit, no number; the forecaster's own chance of this, stated with the estimate: 15%; at least 1.4-fold (0.17 log units) between middle value and limit.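

In this assay compound 4 gives a limit and not a number: the limit of < 0.0667 h in this assay, at which 1 of the 4 values shown sits.

Replacing the ring with an open chain gives an at least 1.1-fold lower number from compound 3 to compound 4 (0.07 log units; that floor lies within the scatter), and likewise an at least 1.1-fold lower number from compound 1 to compound 4 (0.07 log units; that floor lies within the scatter). Among the compounds shown here, on a saturated chain carbon bound to an aromatic carbon and a saturated chain carbon, (isopropylcarbamoyl)methyl therefore gives no longer half-life than either ring group, so the first group without a ring at this place brings no gain.

As far as these compounds go, how far compound 4 lies past its limit stays open. So does whether a primary amine or a carboxylic acid at this place would give a longer half-life.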